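Working notes: from compound 2 to compound 3

The source may hold more compounds than are shown below. What is called first, only, known or untested is meant among the compounds shown, and "the series" means these compounds.

Measured so far in a functional assay on HepG2 cells (Homo sapiens), read by MTT assay, with a stated time of 48 h; a lower number here means a stronger inhibitor, a higher number a weaker inhibitor:
- Compound 1 `CCN(CC)CCCNC(=O)c1ccc(C(CC)(CC)c2ccc(OCC(=O)C(C)(C)C)c(C)c2)n1CC`: 180 nM
- Compound 2 `CCOC(=O)CN(C)C(=O)c1ccc(C(CC)(CC)c2ccc(OCC(O)C(C)(C)C)c(C)c2)n1CC`: > 50000 nM (a limit of the assay, not a number)

Compound 2 stands at the limit of > 50000 nM in this assay, at which 1 of the 2 values shown sits. It therefore has no number of its own, and the gap between it and compound 1 is open-ended.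

Compound 3 `CCn1c(C(=O)NCC(OC)OC)ccc1C(CC)(CC)c1ccc(OCC(O)C(C)(C)C)c(C)c1` follows from compound 2 by a single change, ((2,2-dimethoxyethyl)amino in place of ((ethoxycarbonyl)methyl)(methyl)amino on a carbonyl carbon). In words, (2,2-dimethoxyethyl)amino takes the place of ((ethoxycarbonyl)methyl)(methyl)amino on a carbonyl carbon, and the rest of the structure stays as it is.

Going by the values given here, no measured step sizes this change, so the expectation is rough. Compound 3 is expected to remain weak in this assay because compound 2 reaches the limit > 50000 nM. A small shift towards stronger inhibition is possible, and a result that again gives only a limit would be no surprise. The expected change is an at least 1.6-fold lower number from compound 2 to compound 3 (0.22 log units; that floor lies within the scatter). For compound 3 the estimated value is 30000 nM, with an expected range from 8000 nM to 60000 nM.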

Compound 3, half-maximal inhibitory concentration: 23200 nM
Compound 3: the middle estimate sits 1.3-fold (0.11 log units) above what was measured, and the stated range covers the measured number.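

In this assay, (2,2-dimethoxyethyl)amino in place of ((ethoxycarbonyl)methyl)(methyl)amino on a carbonyl carbon gives an at least 2.1-fold lower number from compound 2 to compound 3 (0.33 log units; beyond the scatter). Going by these compounds alone, this is the only sized step so far, and it shows that the group on this carbonyl carbon, whose other neighbours are aromatic carbon, can move the read-out while the rest of the structure stays fixed, with compound 3 at 23200 nM as the first number for a compound of this pair. The step is only a floor and its true size stays open, because compound 2 has a limit of the assay and not a number of its own: the limit of > 50000 nM in this assay, at which 1 of the 3 values shown sits.

The change swaps several features at once, including the methyl on the nitrogen, the ethyl ester and the amide hydrogen, so the compounds shown do not separate their contributions, and compound 1 differs from compound 3 in more than one place, so no step links them. Also open, on these data alone, is how a carboxylic acid, a primary amine or a longer chain on the same carbonyl carbon would read in this assay.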